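Swapping the amine on the chain of compound 1

A few compounds are considered here, and "the series" means these few. Any claim that something is new, unique, unknown or untested is made for them only; others in the source may bear on it.

Among the compounds with values here, compound 1 `CCN(CC)CN1C(=O)/C(=N\c2nc3ccc(C)cc3s2)c2ccccc21` is one of two compounds measured in a functional assay on MCF7 cells (Homo sapiens) for cytotoxicity, read by sulforhodamine B assay, with a stated time of 48 h (on this read-out higher numbers stand for weaker inhibition of growth and lower numbers for stronger inhibition of growth), where compound 1 gives 74800 nM. Its companion, compound 2 `CCN(CC)CN1C(=O)/C(=N\c2nc3ccc(C)cc3s2)c2c(Br)cccc21`, gives 30200 nM in this assay, so compound 1 holds the highest number of the pair, the weaker of the two at slowing cell growth. Within the data shown here, the one recorded step, a 2.5-fold lower number from compound 1 to compound 2 (0.39 log units; beyond the scatter), concerns bromo in place of hydrogen on an aromatic carbon.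

Compound 3 `Cc1ccc2nc(/N=C3\C(=O)N(CN4CCCCC4)c4ccccc43)sc2c1` differs from compound 1 elsewhere: piperidin-1-yl in place of diethylamino on a saturated chain carbon bound to an amide-type nitrogen in a ring. Among the measured compounds shown here, no measured step touches this part of the molecule, so the bromo step offers no direct guide. With nothing pointing either way, the expectation is a step of a 1.1-fold lower number from compound 1 to compound 3 (0.03 log units; within the scatter), one that stays within the scatter. Compound 3 is therefore estimated at 70000 nM in this assay, expected to fall between 30000 nM and 160000 nM.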

Compound 3, concentration for 50% growth inhibition: 37800 nM
Compound 3: middle estimate off by 1.9-fold (0.27 log units), on the high side, within the range that was stated.
By their numbers in this assay, from the lowest: compounds 2, 3 and 1 (each within the scatter of the next, the first and the last beyond it).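

Exchanging the open diethylamino for the ring of piperidin-1-yl, on a saturated chain carbon bound to an amide-type nitrogen in a ring, gives a 2.0-fold lower number from compound 1 to compound 3 (0.30 log units; within the scatter) in this assay. Within the data shown here, this is the first look at the amine on this chain, and it shows that the open amine can be replaced by a six-membered ring with no change that stands clear of repeat-measurement noise, so this single swap gives no sign that the choice between these two amines matters for growth inhibition. Nothing available accounts for this outcome, whether through the ring or the added carbon.

On these data alone, how a morpholine or pyrrolidine in the same place would read stays open. So does whether the bromo of compound 2 would lower the number when paired with piperidin-1-yl.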